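A Chlorinated Aryl Group Tested Against an Unmoved Limit

This account rests on a few compounds, and the source may have more. Where it says the series, first, only, none or still open, it means among the compounds named here.

Compound 1 `CCOc1ccccc1-n1nncc1CN1C(=O)C2(C(C#N)=C(N)Oc3c2c2nc4ccccc4nc2c2ccccc32)c2ccccc21` and compound 2 `Cc1cccc(-n2nncc2CN2C(=O)C3(C(C#N)=C(N)Oc4c(N)cc5nc6ccccc6nc5c43)c3ccccc32)c1` were both run in an ADME assay on L02 cells (Homo sapiens) for antiproliferative activity, read by MTT assay, with a stated time of 48 h; a lower number here means a stronger inhibitor, a higher number a weaker inhibitor. For compound 1 the result is only a limit, > 50000 nM. For compound 2 the result is likewise a limit, > 50000 nM. Both values thus sit at the limit of > 50000 nM in this assay, at which 2 of the 2 values shown sit, so compound 2 stands exactly where compound 1 stands, with no resolved number for either. Compound 3 `Cc1ccc(-n2nncc2CN2C(=O)C3(C(C#N)=C(N)Oc4c(N)cc5nc6ccccc6nc5c43)c3ccccc32)cc1Cl` carries 3-chloro-4-methylphenyl in place of 3-methylphenyl on an aromatic nitrogen. For the measured compounds named here, with no measured step between resolved numbers to rest on, the change is expected to leave the value within the scatter, a step that the limit leaves unreadable from compound 2 to compound 3. Compound 3 is expected to give 60000 nM, between 20000 nM and 200000 nM, most likely again as a limit.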

Compound 3, half-maximal inhibitory concentration: > 50000 nM
Compound 3: a limit, no number (the forecaster's own chance of this, stated with the estimate: 85%); the middle value lies beyond the limit too.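

For the compounds shown here, no step from compound 2 to compound 3 can be read, since both results are limits and not numbers: the limit of > 50000 nM in this assay, at which 3 of the 3 values shown sit. The compounds shown leave open whether 3-chloro-4-methylphenyl in place of 3-methylphenyl changes the activity at all.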